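A few compounds are considered here, and "the series" means these few. Any claim that something is new, unique, unknown or untested is made for them only; others in the source may bear on it.

Compound 1 `CC1CCN(c2c(S(=O)(=O)c3cc(F)cc(F)c3)cnc3cc(Cl)ccc23)CC1` stands highest among the three compounds measured in an assay on isolated protein for displacement of a labelled ligand from metabotropic glutamate receptor 5 (Homo sapiens), with a stated time of 60 min, tested at 1 uM (a higher number here means more inhibition at the concentration tested (going by the name of the read-out), a lower number less inhibition), where compound 1 gives 94%. Compound 3 `CC1CCN(c2c(S(=O)(=O)c3cccc(F)c3)cnc3c(F)cccc23)CC1` reaches 62% in this assay, a figure beyond the scatter below compound 1, and compound 2 `CN1CCN(c2c(S(=O)(=O)c3ccccc3)cnc3ccccc23)CC1` gives 7.7%, far below both. Compound 4 `Cc1ccc(S(=O)(=O)c2cnc3cc(Cl)ccc3c2N2CCC(C)CC2)cc1F` has not yet been measured. Among the measured compounds shown here, its one change against compound 1 is 3-fluoro-4-methylphenyl in place of 3,5-difluorophenyl on a sulfonyl sulfur. For the measured compounds named here, no step between two measured compounds isolates this kind of change, so the expectation rests on compound 1 alone. A small downward step, at the edge of the scatter, is expected from compound 1 to compound 4, a number 9 percentage points lower from compound 1 to compound 4 (within the scatter). Compound 4 is therefore estimated to give about 85% in this assay, within a range of 60% to 97%.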

Compound 4, a percentage reported as inhibition, at one concentration (the size of the read-out at that concentration, not a potency): 85%
Compound 4: middle estimate and measured number agree at the digits printed; the range from low to high includes it.
By their numbers in this assay, from the lowest: compound 2; then compound 3; then compounds 4 and 1 (each within the scatter of the next).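

In this assay, the group on the sulfonyl sulfur now has its first one-place comparison: 3-fluoro-4-methylphenyl in place of 3,5-difluorophenyl gives a number 9 percentage points lower from compound 1 to compound 4 (within the scatter). This sulfonyl position therefore keeps high inhibition through this exchange, with one fluorine fewer and one methyl added on the ring. No measurement here bears on the reason for this. Still open, going by these compounds, is whether a methoxy group, a nitrile or a pyridine ring would be accepted at this position. A single-concentration read-out this high also leaves any potency difference between these two compounds unresolved.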